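Solubility of a Dimethylpyridinyl Ether Analogue

The source may hold more compounds than are shown below. What is called first, only, known or untested is meant among the compounds shown, and "the series" means these compounds.

Measured compounds:
Compound 1, `Cn1c(COc2cccc(C(=O)O)c2)nc2cnc(Oc3ccc4c(c3)OCC4)cc21`: 79 ug/mL
Compound 2, `Cn1c(COc2cccc(C(=O)O)c2)nc2ccc(Oc3ccccn3)cc21`: 62 ug/mL

In a physicochemical assay for solubility, read by HPLC, measured as thermodynamic solubility, with a stated time of 4 h, at pH 6.8 (a higher number here means a more soluble compound, a lower number a less soluble compound), compound 1 gives 79 ug/mL and compound 2 gives 62 ug/mL. Compound 2 has the lowest of the two numbers, but its nearest neighbour, compound 1, sits only a small gap above it, and that gap lies within the usual scatter of this assay, so the two compounds cannot be told apart on solubility.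

Compound 3, `Cc1ccc(Oc2ccc3nc(COc4cccc(C(=O)O)c4)n(C)c3c2)nc1C`, has not yet been measured. It differs from compound 2 in one place:
5,6-dimethylpyridin-2-yl in place of pyridin-2-yl on an oxygen on an aromatic ring
Among the measured compounds shown here, no step between measured compounds shows this kind of change, so the expectation rests on the structural change alone. Compound 3 is expected to give a lower number than compound 2 in this assay, with a step from compound 2 to compound 3 estimated at a 2.1-fold lower number from compound 2 to compound 3 (0.32 log units; beyond the scatter), a modest fall that may only just clear the scatter. Compound 3 is therefore estimated at 30 ug/mL, with a range from 12 ug/mL to 75 ug/mL.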

Compound 3, solubility: 190 ug/mL
Compound 3: the middle estimate sits 6.3-fold (0.80 log units) below what was measured; measured number outside the range, above it.
By their numbers in this assay, from the lowest: compounds 2 and 1 (each within the scatter of the next); then compound 3.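

In this assay, the place on an oxygen on an aromatic ring proves able to move the read-out: 5,6-dimethylpyridin-2-yl in place of pyridin-2-yl goes with a 3.1-fold higher number from compound 2 to compound 3 (0.49 log units; beyond the scatter). The earlier compounds shown here offered no step of this kind, and this first one shows that at this place, a larger group, with 8 heavy atoms against 6 and the same count of hydrogen-bond acceptors, can go with a higher number rather than a lower one, by a margin beyond the scatter. Nothing available accounts for the rise, so the step stands as an observation without an explanation.

A single step cannot tell whether both methyl groups are needed for the rise or whether one alone would carry it, nor whether the same change would read the same way on the core of compound 1. The compounds shown also leave open how an amine or a longer chain on the pyridin-2-yl group would read in this assay.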